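The source may hold more compounds than are shown below. What is called first, only, known or untested is meant among the compounds shown, and "the series" means these compounds.

Of the compounds shown here, two share one core and have been tested in an ADME assay on Caco-2 cells (Homo sapiens) for permeability, in the apical to basolateral direction; on this read-out higher numbers stand for higher permeability and lower numbers for lower permeability. Compound 1 `CC(=O)N1CCN([C@H]2CC[C@H](Nc3ncnn4ccc([C@H]5CC[C@H](C(N)=O)CC5)c34)CC2)CC1` gives < 0.7 10^-6 cm/s, which is a limit of the assay and not a number. Among the measured compounds shown here, compound 2 `CC(=O)N1CCN([C@H]2CC[C@H](Nc3ncnn4ccc(C(C)C)c34)CC2)CC1` gives 38 10^-6 cm/s, the only true number so far. Compound 3 `CC(=O)N1CCN([C@H]2CC[C@H](Nc3ncnn4ccc(C5CCOCC5)c34)CC2)CC1` has not yet been measured, and it differs from compound 2 at one place: oxan-4-yl in place of isopropyl on an aromatic carbon. For the measured compounds named here, only one measured step bears on this aromatic carbon: an at least 54-fold higher number from compound 1 to compound 2 (1.73 log units; beyond the scatter), with isopropyl in place of 4-carbamoylcyclohexyl. Like compound 1, compound 3 carries a six-membered non-aromatic ring there, but it has no carbamoyl group, so a much smaller change than that large step is expected. The expected step is a modest fall close to the usual scatter, estimated as a 2.1-fold lower number from compound 2 to compound 3 (0.32 log units; beyond the scatter). For compound 3 the estimated value is 18 10^-6 cm/s, with an expected range from 7 10^-6 cm/s to 38 10^-6 cm/s.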

Compound 3, apparent permeability: 30 10^-6 cm/s
For compound 3 the middle estimate is 1.7-fold (0.22 log units) below the measured one; measured number inside the range.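

In this assay, replacing isopropyl with oxan-4-yl gives a 1.3-fold lower number from compound 2 to compound 3 (0.10 log units; within the scatter), so this change, which adds a six-membered non-aromatic ring with one hydrogen-bond acceptor, brings no real difference in the read-out. A six-membered non-aromatic ring on this aromatic carbon therefore does not by itself go with a low number, as the comparison with 4-carbamoylcyclohexyl also shows: an at least 42-fold higher number from compound 1 to compound 3 (1.63 log units; beyond the scatter). Compound 1 gives a limit of the assay and not a number, so that step has no upper end: the limit of < 0.7 10^-6 cm/s in this assay, at which 1 of the 3 values shown sits.

As far as these compounds go, it remains open which part of 4-carbamoylcyclohexyl goes with the limit, the ring or the carbamoyl group, and a plain cyclohexyl would separate the two. From the compounds shown here alone, how an amine or a carboxylic acid on this aromatic carbon would read is also open.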